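A few compounds are considered here, and "the series" means these few. Any claim that something is new, unique, unknown or untested is made for them only; others in the source may bear on it.

Measured so far:
Compound 1, `COc1ccc(-n2nc(C(=O)Nc3ccc(Oc4ccnc5cc(OCCCN6CCCCC6)c(OC)cc45)c(F)c3)c(C)cc2=O)cc1`: 1800 nM
Compound 2, `COc1cc2c(Oc3ccc(NC(=O)c4nn(-c5ccc(Cl)cc5)c(=O)cc4C)cc3F)ccnc2cc1OCCCN1CCCC1`: 1430 nM

In a functional assay on U-87MG ATCC cells (Homo sapiens) for inhibition, read by MTT assay, with a stated time of 72 h (a higher number here means a weaker inhibitor, a lower number a stronger inhibitor), compound 1 gives 1800 nM. In this assay compound 2 gives 1430 nM, and the two numbers lie within the usual scatter of each other, so neither compound can be set apart from the other on these data. Among the measured compounds shown here, compound 1 and compound 2 differ in two places at once, and no single step between them has been recorded.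

Compound 3, `COc1cc2c(Oc3ccc(NC(=O)c4nn(-c5ccc(Cl)cc5)c(=O)cc4C)cc3F)ccnc2cc1OCCCN1CCCCC1`, is the next compound to be measured in this assay. It keeps the core of compound 2 and differs from it in one place: piperidin-1-yl in place of pyrrolidin-1-yl on a saturated chain carbon, three bonds along the chain from an oxygen on an aromatic ring. Compound 1 already carries the piperidin-1-yl group on the same chain, with a different group on the other end of the molecule, and its value sits close to that of compound 2.

On this basis the step of a 1.1-fold lower number from compound 2 to compound 3 (0.04 log units; within the scatter) is expected to stay small, in either direction, and not to go beyond the scatter. For compound 3 a value of 1300 nM is estimated, within a range from 600 nM to 3000 nM.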

Compound 3, half-maximal inhibitory concentration: 1400 nM
Estimate against measurement, compound 3: 1.1-fold (0.03 log units) below; measured number inside the range.
By their numbers in this assay, from the lowest: compounds 3, 2 and 1 (each within the scatter of the next).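

In this assay, piperidin-1-yl in place of pyrrolidin-1-yl on a saturated chain carbon, three bonds along the chain from an oxygen on an aromatic ring, gives a 1.0-fold lower number from compound 2 to compound 3 (0.01 log units; within the scatter). Among the compounds shown here, this is the first reading of that exchange as a single change, since compound 1 and compound 2 differ in two places at once; with the far end of the molecule held constant, the two ring amines cannot be told apart in this cell read-out. Compound 3 also isolates the other difference, with chloro in place of methoxy on an aromatic carbon giving a 1.3-fold lower number from compound 1 to compound 3 (0.11 log units; within the scatter), and nothing measured here bears on why either exchange leaves the number within the scatter.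

From the compounds shown here alone, it remains open whether morpholin-4-yl, 4-methylpiperazin-1-yl or an open-chain dimethylamino group at the end of the same chain would also stay within the scatter, and whether a 2-(piperidin-1-yl)ethyl group in place of 3-(piperidin-1-yl)propyl would do so. The compounds shown also leave open what a trifluoromethyl group, a fluoro group or a plain hydrogen would give in place of chloro on that aromatic carbon.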